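Swapping the Piperazine Substituent: From Aryl to Cyclohexyl

A few compounds are considered here, and "the series" means these few. Any claim that something is new, unique, unknown or untested is made for them only; others in the source may bear on it.

Compound 3 `Cc1ccc(N2CCN(C(=S)SCc3ccc(C(=O)Nc4ccccc4N)cc3)CC2)cc1` gives 25.3% in a functional assay on HeLa cells (Homo sapiens) for antiproliferative activity, read by CCK-8 assay, with a stated time of 72 h, tested at 2 uM (a higher number here means a stronger effect of the compound at the concentration tested, a lower number a weaker effect), the lowest of the three measured numbers. Compound 1 `Nc1ccccc1NC(=O)c1ccc(CSC(=S)N2CCN(c3cccnc3)CC2)cc1` gives 66.2% and compound 2 `Nc1ccccc1NC(=O)c1ccc(CSC(=S)N2CCN(c3ccc(F)cc3)CC2)cc1` gives 60.8%; the step of a number 5.4 percentage points lower from compound 1 to compound 2 (within the scatter) is small, whereas a number 40.9 percentage points lower from compound 1 to compound 3 (beyond the scatter) and a number 35.5 percentage points lower from compound 2 to compound 3 (beyond the scatter) are both large. Compound 4 `Nc1ccccc1NC(=O)c1ccc(CSC(=S)N2CCN(C3CCCCC3)CC2)cc1` changes the same position: cyclohexyl in place of 4-methylphenyl on an amine nitrogen in a ring. Within the data shown here, the two large steps, both of which bring in 4-methylphenyl, bear on this change, but no measured step replaces an aromatic ring with a non-aromatic one, so the direction is only a guess. Compound 4 is expected to give about 45%, within 15% to 75%, meaning an expected step of a number 19.7 percentage points higher from compound 3 to compound 4 (beyond the scatter) in this assay.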

Compound 4, a percentage reported as inhibition, at one concentration (the size of the read-out at that concentration, not a potency): 30.6%
The estimate for compound 4 lay 14.4 percentage points above the measured number; the measured number falls inside the stated range.
By their numbers in this assay, from the lowest: compounds 3 and 4 (each within the scatter of the next); then compounds 2 and 1 (each within the scatter of the next).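

In this assay cyclohexyl in place of 4-methylphenyl gives a number 5.3 percentage points higher from compound 3 to compound 4 (within the scatter) and so shows that a non-aromatic carbon ring and this aromatic ring cannot be told apart at this position. Cyclohexyl in place of 4-fluorophenyl gives a number 30.2 percentage points lower from compound 2 to compound 4 (beyond the scatter) and in place of pyridin-3-yl gives a number 35.6 percentage points lower from compound 1 to compound 4 (beyond the scatter) as well. An aromatic ring alone therefore does not bring the higher numbers, since compound 3 has one and still sits low with compound 4. Where a piperidine ring bearing an amine or an open butyl chain would fall at this position remains open. No measurement shown here explains why these groups separate as they do.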